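A Larger Carbon Ring on the Carbonyl

This account rests on a few compounds, and the source may have more. Where it says the series, first, only, none or still open, it means among the compounds named here.

Values measured in a physicochemical assay for lipophilicity, read by HPLC, measured as chromatographic lipophilicity, at pH 7.4; on this read-out higher numbers stand for higher lipophilicity and lower numbers for lower lipophilicity:
Compound 1 `O=C(C1CCCC1)N1N=CCC1c1ccccc1`: 5.4
Compound 2 `CC(C)(C)C(=O)N1CCC1c1ccccc1`: 5
Compound 3 `CC(=O)N1CCC(C(=O)N2N=CC[C@H]2c2ccccc2)CC1`: 2.5

Compound 1 stands highest of these three. Compound 2, at 5, lies lower, beyond the usual scatter of repeated measurements. Compound 3, at 2.5, lies furthest from compound 1, also beyond the scatter.

Compound 4 `O=C(C1CCCCC1)N1N=CCC1c1ccccc1` has not yet been measured. It keeps the core of compound 1 but carries cyclohexyl in place of cyclopentyl on a carbonyl carbon. For the measured compounds named here, no measured pair here shows this kind of change, so any forecast rests on the structures alone. Both rings are made of carbon only, and neither brings hydrogen-bond donors or acceptors. In this assay, a small rise is expected, slightly beyond the scatter, starting from compound 1 at 5.4. The estimated step of a number 0.40 log units higher from compound 1 to compound 4 (beyond the scatter) could still turn out to lie within the scatter. The estimate for compound 4 is 5.8, with an expected range from 5.4 to 6.2.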

Compound 4, distribution coefficient: 5.9
The estimate for compound 4 lay 0.10 log units below the measured number; the range from low to high includes it.
By their numbers in this assay, from the lowest: compound 3; then compound 2; then compound 1; then compound 4.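

For the compounds shown here, exchanging cyclopentyl for cyclohexyl on a carbonyl carbon gives, in this assay, a number 0.50 log units higher from compound 1 to compound 4 (beyond the scatter) and so supplies the first comparison here between compounds that differ in one place. It shows that this position responds when a five-membered ring of carbon only gives way to a six-membered one, even though neither group carries hydrogen-bond donors, hydrogen-bond acceptors or a net charge. No measurement shown here explains why the number moves.

This single pair cannot show whether a larger carbon ring such as cycloheptyl would carry the numbers further in the same direction. From the compounds shown here alone, how an open-chain pentyl group, or a cyclohexyl ring bearing an amine or a carboxylic acid, would read at this position also remains open.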